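A few compounds are considered here, and "the series" means these few. Any claim that something is new, unique, unknown or untested is made for them only; others in the source may bear on it.

For the measured compounds named here, compound 3 `COc1cc(-c2cnn3cc(OC)c(C4CCCC4)nc23)ccn1` is one of three compounds measured in an ADME assay on microsomes from liver (Homo sapiens) for metabolic stability, with a stated time of 60 min, tested at 1 uM; a lower number here means that less of the compound is left, a higher number that more of the compound is left. Compound 1 `Cn1cc(-c2nc3c(-c4ccnc(OC5CC5)c4)cnn3cc2OCC(C)(C)O)cn1` gives 53% in this assay. Compound 2 `COc1cc(-c2cnn3cc(OC)c(-c4cc(C)no4)nc23)ccn1` gives 31%. Compound 3 gives 32%. Compound 2 and compound 3 share a core and differ in a single group, cyclopentyl in place of 3-methyl-1,2-oxazol-5-yl on an aromatic carbon, and that change gave a number 1 percentage points higher from compound 2 to compound 3 (within the scatter). Compound 3 thus stands second highest of the three numbers, close to compound 2 and clearly under compound 1.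

Compound 4 `COc1cnc2c(-c3ccnc(OC)c3)cnn2c1` is reached from compound 3 by a simpler change: hydrogen in place of cyclopentyl on an aromatic carbon. Going by the values given here, the only measured step at this aromatic carbon, cyclopentyl in place of 3-methyl-1,2-oxazol-5-yl, gave a number 1 percentage points higher from compound 2 to compound 3 (within the scatter), so exchanging the group there has so far left the read-out in place. Replacing the cyclopentyl by hydrogen has no direct precedent among these compounds, and compound 1, built on a different core, offers no guide. The step is therefore expected to be a number 6 percentage points higher from compound 3 to compound 4 (within the scatter), with no confident direction. Compound 4 is estimated at 38%, between 22% and 55%.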

Compound 4, percent of the compound remaining: 2%
Estimate against measurement, compound 4: 36 percentage points above, and the stated range ends above it.
By their numbers in this assay, from the lowest: compound 4; then compounds 2 and 3 (each within the scatter of the next); then compound 1.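

In this assay the aromatic carbon that carried cyclopentyl had looked indifferent, since exchanging one group for another there left the number in place, but with hydrogen at that carbon the picture changes: the data show a number 30 percentage points lower from compound 3 to compound 4 (beyond the scatter) and a number 29 percentage points lower from compound 2 to compound 4 (beyond the scatter) for the same replacement. Cyclopentyl and 3-methyl-1,2-oxazol-5-yl differ greatly yet stand level with each other, and both stand clear of hydrogen, so among these three compounds having a group on this carbon goes with more compound left. Nothing at hand explains this drop.

Still open, on these data alone, is whether any group on this carbon would serve, or only one as large as these two; a chlorine or an amine there would help to decide. Compound 1 differs from the others in more than one place, so it cannot show how much of its higher number belongs to this position.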